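The compounds below may be only part of what the source reports. "The series", "measured", "known", "first", "only" and "open" are said of these compounds alone.

Measured in an ADME assay on MDBK cells (Bos taurus) for cytotoxicity; a lower number here means that less compound is tolerated, a higher number that more compound is tolerated:
Compound 1 `COc1ccccc1Cn1ccc2nc(-c3ccccc3)nc-2c1`: > 100000 nM
Compound 2 `CC(C)N(CCn1ccc2nc(-c3ccccc3)nc-2c1)C(C)C`: > 100000 nM

In this assay compound 2 gives > 100000 nM, which is a limit of the assay and not a number. Compound 1 gives > 100000 nM, which is also a limit. Compound 3 `C(=C/c1ccccc1)\Cn1ccc2nc(-c3ccccc3)nc-2c1` differs from compound 2 by 2-phenylethenyl in place of (diisopropylamino)methyl on a saturated chain carbon bound to an aromatic nitrogen: 2-phenylethenyl stands in place of (diisopropylamino)methyl on a saturated chain carbon bound to an aromatic nitrogen. Going by the values given here, the only measured step is a step that the two limits leave unreadable from compound 1 to compound 2, so it offers no size to carry over. It still bears on the change, as 2-methoxyphenyl and (diisopropylamino)methyl both leave the measured compounds at the limit of > 100000 nM in this assay, at which 2 of the 2 values shown sit. No step beyond the scatter is therefore expected in this assay, and no direction can be given. The expected step is a number no higher from compound 2 to compound 3 (the limit leaves the size open). For compound 3 the estimate is 100000 nM, with an expected range from 35000 nM to 200000 nM.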

Compound 3, half-maximal cytotoxic concentration: 78000 nM
Compound 3: the middle estimate sits 1.3-fold (0.11 log units) above what was measured; the measured number falls inside the stated range.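

Going by these compounds alone, with compound 3, this position gives a readable number in this assay for the first time, where the earlier compounds gave only limits. Placing 2-phenylethenyl on the saturated chain carbon bound to an aromatic nitrogen gives an at least 1.2-fold lower number from compound 2 to compound 3 (0.10 log units; that floor lies within the scatter), and the same group gives an at least 1.2-fold lower number from compound 1 to compound 3 (0.10 log units; that floor lies within the scatter). Neither floor shows a real difference, and the full size of each step stays open, since both comparison compounds rest on a limit and not a number: the limit of > 100000 nM in this assay, at which 2 of the 3 values shown sit.

The compounds shown leave open whether the double bond of 2-phenylethenyl matters, which a saturated 2-phenylethyl group would test. They also leave open whether a carboxylic acid or a longer chain ending in a primary amine at this position would give a step beyond the scatter.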